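The compounds below may be only part of what the source reports. "The series", "measured", "known", "first", "only" and "open" are said of these compounds alone.

Of the compounds shown here, two of one series have been measured in an assay on isolated protein for displacement of a labelled ligand from metabotropic glutamate receptor 5 (Homo sapiens), with a stated time of 60 min, tested at 1 uM; on this read-out lower numbers stand for less inhibition and higher numbers for more inhibition at the one concentration tested (going by the name of the read-out). Compound 1 `Cc1ccc2ncc(S(=O)(=O)c3cccc(C#N)c3)c(N3CCC(C)CC3)c2c1` gives 52% in this assay. Compound 2 `CC1CCN(c2c(S(=O)(=O)c3ccc(Cl)cc3)cnc3ccc(Cl)cc23)CC1` gives 92% in this assay, the higher of the two numbers, and its gap to compound 1 lies beyond the usual scatter. For the measured compounds named here, no step between measured compounds that differ in one place exists, since compound 1 and compound 2 differ in two places. Compound 3 `CC1CCN(c2c(S(=O)(=O)c3cccc(C#N)c3)cnc3ccc(Cl)cc23)CC1` carries the change (3-cyanophenyl in place of 4-chlorophenyl on a sulfonyl sulfur). Going by the values given here, this group on the sulfonyl sulfur is the one found in compound 1, whose 52% stands well below the number for compound 2, although compound 1 also differs elsewhere, so how much of the lower number belongs to that group alone is unknown. A downward step in this assay, probably beyond the scatter yet smaller than the whole gap to compound 1, is expected from compound 2 to compound 3, a number 20 percentage points lower from compound 2 to compound 3 (beyond the scatter). For compound 3 the estimate is 72%, within a range of 50% to 90%.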

Compound 3, a percentage reported as inhibition, at one concentration (the size of the read-out at that concentration, not a potency): 90%
The estimate for compound 3 lay 18 percentage points below the measured number; low and high end bracket the measured number.
By their numbers in this assay, from the lowest: compound 1; then compounds 3 and 2 (each within the scatter of the next).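

With the chloro-bearing core held fixed, 3-cyanophenyl in place of 4-chlorophenyl on a sulfonyl sulfur gives a number 2 percentage points lower from compound 2 to compound 3 (within the scatter) in this assay, so this position accepts either group on this read-out. For the compounds shown here, the low number of compound 1 therefore does not follow from the 3-cyanophenyl group alone: chloro in place of methyl on an aromatic carbon gives a number 38 percentage points higher from compound 1 to compound 3 (beyond the scatter), and the large change so far lies at that carbon. Nothing available explains either step.

On these data alone, whether a methoxy group or an amine on that aromatic carbon would behave like chloro or like methyl remains open. Also open, as far as these compounds go, is whether compound 2 and compound 3 would still match in potency, since a single-concentration read-out does not give one.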